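Compound 4 and the trimethoxyphenyl swap

A few compounds are considered here, and "the series" means these few. Any claim that something is new, unique, unknown or untested is made for them only; others in the source may bear on it.

Compound 1 `O=C(N/N=C/c1ccc(F)cc1)Nc1cc2c(Nc3ccc(F)c(Cl)c3)ncnc2cc1O[C@H]1CCOC1`: 28200 nM
Compound 2 `O=C(N/N=C/c1ccc([N+](=O)[O-])cc1)Nc1cc2c(Nc3ccc(F)c(Cl)c3)ncnc2cc1O[C@H]1CCOC1`: "not active" (no number reported)
Compound 3 `COc1cc2ncnc(Nc3ccc(F)c(Cl)c3)c2cc1NC(=O)N/N=C/c1ccc([N+](=O)[O-])cc1`: 36800 nM

In a functional assay on MCF7 cells (Homo sapiens) for cytotoxicity, read by MTT assay, with a stated time of 72 h (a lower number here means a stronger inhibitor, a higher number a weaker inhibitor), compound 3 gives 36800 nM, which lies within the scatter of compound 1 at 28200 nM. Compound 2 is recorded as "not active" (no number reported) and offers no number for comparison.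

Compound 4 `COc1cc2ncnc(Nc3ccc(F)c(Cl)c3)c2cc1NC(=O)N/N=C/c1cc(OC)c(OC)c(OC)c1` carries 3,4,5-trimethoxyphenyl in place of 4-nitrophenyl on a carbon with a double bond to nitrogen. Going by the values given here, no measured pair differs at this place alone, and the data therefore give no direct guide to the size of this change. No shift beyond the scatter is expected in either direction.

The estimated move is a 1.2-fold lower number from compound 3 to compound 4 (0.09 log units; within the scatter).

For compound 4 the expected value in this assay is 30000 nM, with an estimated range from 10000 nM to 90000 nM.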

Compound 4, half-maximal inhibitory concentration: 30700 nM
For compound 4 the middle estimate is 1.0-fold (0.01 log units) below the measured one; the measured number falls inside the stated range.
By their numbers in this assay, from the lowest: compounds 1, 4 and 3 (each within the scatter of the next).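

At the carbon with a double bond to nitrogen, this assay now gives a first readable step, a 1.2-fold lower number from compound 3 to compound 4 (0.08 log units; within the scatter), for 3,4,5-trimethoxyphenyl in place of 4-nitrophenyl. The earlier compounds shown here offered no such pair, and this one shows that these two aryl groups cannot be told apart at this place on the shared core. Nothing measured accounts for this result. Still open, going by these compounds, is whether a group other than a substituted phenyl, such as a piperidine or a benzoic acid, would give a number beyond the scatter here.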